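The source may report more compounds than this note shows. Statements on the series, on what has been measured and on what is new or still open speak of the compounds shown alone.

Of the compounds shown here, three have been measured. Compound 1 is `CC(C)c1cc(Nc2cc(Cl)cc(Cl)c2)nc(N)n1`, compound 2 is `Cc1cc(Nc2cc(Cl)cc(Cl)c2)ncn1`, and compound 3 is `CNc1nc(C)cc(Nc2cc(Cl)cc(Cl)c2)n1`. In an assay on cells for inhibition of S-adenosylmethionine decarboxylase proenzyme (Homo sapiens), read by mass spectrometry, at pH 7.2 (on this read-out lower numbers stand for stronger inhibition and higher numbers for weaker inhibition), compound 1 gives only a limit, > 180000 nM. In this assay compound 2 also gives only a limit, > 180000 nM. Compound 3 in turn gives only a limit, > 63000 nM. So compound 3 stands at a limit, as do the other two, and no measured compound has a number. Within the data shown here, the one step between compounds that differ in a single place, a step that the two limits leave unreadable from compound 2 to compound 3, is of a size the two limits leave unreadable. The whole of the evidence is the limit of > 180000 nM in this assay, at which 2 of the 3 values shown sit, and (the limit of > 63000 nM in this assay, at which 1 of the 3 values shown sits).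

Compound 4, `Cc1cc(Nc2cc(Cl)cc(Cl)c2)nc(N(C)C)n1`, is the next compound. It differs from compound 3 by methyl in place of hydrogen on a nitrogen on an aromatic ring. Among the measured compounds shown here, no measured step bears on this change in a readable way, since a step that the two limits leave unreadable from compound 2 to compound 3 is itself unreadable, so no direction can be drawn from it. Compound 3 sits at a limit, and compound 4 is therefore expected to stay near that limit, a step that the limit leaves unreadable from compound 3 to compound 4 that is not expected to go beyond the scatter. Compound 4 is estimated at 200000 nM, within 40000 nM to 1000000 nM, and is most likely to be reported again only as a limit.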

Compound 4, half-maximal inhibitory concentration: > 180000 nM
Compound 4 gave a limit, no number; the forecaster's own chance of this, stated with the estimate: 85%; the middle value does not contradict the limit.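

In this assay compound 4 gives > 180000 nM, which is a limit and not a number. The steps linking compound 2, compound 3 and compound 4 all rest on limits and cannot be read. The compounds shown leave open whether any change on the shared core gives a measured number in this assay, and in which direction any of these changes moves inhibition.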